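This account rests on a few compounds, and the source may have more. Where it says the series, first, only, none or still open, it means among the compounds named here.

Compound 2, drawn as `Oc1nc(OCc2ccccc2)c2nn[nH]c2n1`, is the starting point of this step. In an assay on isolated protein for inhibition of Myeloperoxidase (Homo sapiens), read by fluorescence, with stated times of 10 min, 30 s and 5 min (a lower number here means a stronger inhibitor, a higher number a weaker inhibitor), compound 2 gives > 13000 nM, which is a limit of the assay rather than a measured number. Its nearest relative, compound 1, drawn as `c1ccc(COc2ncnc3[nH]nnc23)cc1`, differs from it only by a hydroxy in place of hydrogen on an aromatic carbon. In this assay compound 1 gives > 13000 nM, again a limit. The step that the two limits leave unreadable from compound 1 to compound 2 therefore cannot be read as a size, because the limit of > 13000 nM in this assay, at which 2 of the 2 values shown sit, describes where both values sit.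

Compound 3, drawn as `CCNc1nc(OCc2ccccc2)c2nn[nH]c2n1`, carries ethylamino in place of hydroxy on an aromatic carbon, in words an ethylamino in place of hydroxy on an aromatic carbon. No measured step among these compounds touches that position with such a group, and the one step that exists gives no readable size, so there is nothing to set a direction or a magnitude for this assay.

Compound 3 is accordingly expected to give about 15000 nM, somewhere in the range 3000 nM to 60000 nM. This estimate means a step that the limit leaves unreadable from compound 2 to compound 3 expected to stay close to where compound 2 already stands.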

Compound 3, half-maximal inhibitory concentration: 2900 nM
Beside the measured number, compound 3's estimate is 5.2-fold (0.71 log units) above it; measured number below the stated range.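

In this assay, the change from hydroxy to ethylamino gives an at least 4.4-fold lower number from compound 2 to compound 3 (0.65 log units; beyond the scatter), and ethylamino in place of hydrogen gives an at least 4.4-fold lower number from compound 1 to compound 3 (0.65 log units; beyond the scatter). This shows that the group on this aromatic carbon, which lies between two ring nitrogen atoms, can shift the number beyond the usual scatter, something the unreadable step between the first two compounds could not show. Each step gives only a minimum size, and the full size remains unknown because each starts from a limit of the assay rather than a measured number: the limit of > 13000 nM in this assay, at which 2 of the 3 values shown sit.

The compounds shown do not separate the contribution of the nitrogen attached to the ring from that of the ethyl chain it carries, which a plain amine or a methylamino group at this place could help to resolve. From the compounds shown here alone, it also remains open whether a longer chain such as propylamino would lower the number further, and whether an ethoxy group, with oxygen in place of that nitrogen, would give a similar value.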